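The source may hold more compounds than are shown below. What is called first, only, known or untested is meant among the compounds shown, and "the series" means these compounds.

Measured in an assay on cell membranes for displacement of a labelled ligand from Neuronal acetylcholine receptor; alpha4/beta2 (Rattus norvegicus); on this read-out higher numbers stand for weaker inhibition and lower numbers for stronger inhibition:

- compound 2 `Oc1ccc(Nc2cncc(N3CC4CC(C3)N4)c2)cc1` gives 0.342 nM
- compound 1 `O=[N+]([O-])c1ccc(Nc2ccc(N3CC4CC(C3)N4)cn2)cc1` gives 1.76 nM
- compound 3 `Fc1ccc(Nc2ccc(N3CC4CC(C3)N4)nn2)cc1` gives 868 nM

Among these three, compound 2 has the lowest number in this assay, and so the strongest inhibition. Compound 1 sits closest to it, though the gap lies beyond the usual scatter of repeated measurements, while compound 3 lies far higher. Compounds 1 and 3 each differ from compound 2 in more than one place, so none of these gaps can be laid at the door of a single change.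

Compound 4 `c1ccc(Nc2cncc(N3CC4CC(C3)N4)c2)cc1` is the compound that has not yet been measured. It is compound 2 with one alteration: hydrogen in place of hydroxy on an aromatic carbon. Among the measured compounds shown here, no measured pair in this set shows this same change on its own, so the direction and size of the step can only be guessed. Losing the hydroxy removes the one hydrogen-bond donor and acceptor that this group contributed, and the expectation is a moderate move toward weaker inhibition, somewhat beyond the scatter, rather than a collapse toward the level of compound 3. The estimated step from compound 2 to compound 4 is a 2.9-fold higher number from compound 2 to compound 4 (0.47 log units; beyond the scatter). Compound 4 is therefore expected to give about 1 nM in this assay, within a range from 0.3 nM to 4 nM.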

Compound 4, inhibition constant: 0.0807 nM
Beside the measured number, compound 4's estimate is 12-fold (1.09 log units) above it; the whole stated range lies above it.
By their numbers in this assay, from the lowest: compound 4; then compound 2; then compound 1; then compound 3.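

In this assay, putting hydrogen in place of hydroxy on the aromatic carbon gives a 4.2-fold lower number from compound 2 to compound 4 (0.63 log units; beyond the scatter) and this modest step lies beyond the usual scatter. On this core, then, the 4-hydroxyphenyl group is not required for strong inhibition: the plain phenyl of compound 4 has the lowest number of the four compounds, even with the hydroxy's hydrogen-bond donor and acceptor gone. Nothing in the data presented accounts for this step, so it stands as an observation without an explanation.

As far as these compounds go, it remains open how other groups on that same carbon, such as methoxy, an amine or fluorine, would compare with hydrogen and hydroxy. From the compounds shown here alone, it also remains open whether the same change would shift the number in the same direction on the cores of compound 1 and compound 3.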